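Adding a Phenyl Group to the Tetrazole of Compound 3

The source may hold more compounds than are shown below. What is called first, only, known or untested is meant among the compounds shown, and "the series" means these compounds.

Three compounds share one core and differ only in the group on a saturated chain carbon bound to a saturated ring carbon. In a functional assay on HUVEC cells (Homo sapiens), read by scintillation counting and thymidine incorporation, with a stated time of 24 h (on this read-out lower numbers stand for stronger inhibition and higher numbers for weaker inhibition), compound 1 `CCC(C)n1ncn(-c2ccc(N3CCN(c4ccc(OC[C@@H]5CO[C@@](Cn6nc(C)nc6C)(c6ccc(Cl)cc6Cl)O5)cc4)CC3)cc2)c1=O` gives 221 nM. Under the same test, compound 2 `CCC(C)n1ncn(-c2ccc(N3CCN(c4ccc(OC[C@@H]5CO[C@@](Cn6cc(C(F)(F)F)nc6C)(c6ccc(Cl)cc6Cl)O5)cc4)CC3)cc2)c1=O` gives 441 nM, and compound 3 `CCC(C)n1ncn(-c2ccc(N3CCN(c4ccc(OC[C@@H]5CO[C@@](Cn6ncnn6)(c6ccc(Cl)cc6Cl)O5)cc4)CC3)cc2)c1=O` gives 124 nM.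

Compound 3 has no real lead over one neighbour, as a 1.8-fold lower number from compound 1 to compound 3 (0.25 log units; within the scatter) shows. Its gap to the other is real but modest: a 3.6-fold lower number from compound 2 to compound 3 (0.55 log units; beyond the scatter). The remaining comparison, a 2.0-fold higher number from compound 1 to compound 2 (0.30 log units; within the scatter), also shows little movement.

The next structure is compound 4 `CCC(C)n1ncn(-c2ccc(N3CCN(c4ccc(OC[C@@H]5CO[C@@](Cn6nnnc6-c6ccccc6)(c6ccc(Cl)cc6Cl)O5)cc4)CC3)cc2)c1=O`, reached through (5-phenyl-1H-tetrazol-1-yl in place of 2H-tetrazol-2-yl on a saturated chain carbon bound to a saturated ring carbon). The 5-phenyl-1H-tetrazol-1-yl group keeps a five-membered aromatic ring with 4 hetero atoms and brings in one six-membered aromatic ring of carbon only.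

Among the compounds with values here, no measured step adds such a ring, so these steps give only a rough guide to size. The largest, a 3.6-fold lower number from compound 2 to compound 3 (0.55 log units; beyond the scatter), suggests that a modest step is the most to expect in this assay. Since compound 3 already gives 124 nM, the low end of this small set, an upward move seems more likely than a downward one.

The expected step is a 2.1-fold higher number from compound 3 to compound 4 (0.32 log units; beyond the scatter). For compound 4, the estimate is 260 nM, with an expected range of 90 nM to 750 nM.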

Compound 4, half-maximal inhibitory concentration: 119 nM
For compound 4 the middle estimate is 2.2-fold (0.34 log units) above the measured one; the range from low to high includes it.
By their numbers in this assay, from the lowest: compounds 4, 3, 1 and 2 (each within the scatter of the next, the first and the last beyond it).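

In this assay, the six-membered aromatic ring of carbon only that enters with 5-phenyl-1H-tetrazol-1-yl gives a 1.0-fold lower number from compound 3 to compound 4 (0.02 log units; within the scatter), so this position, on a saturated chain carbon bound to a saturated ring carbon, can carry a clearly larger group with no readable difference in the result. Within the data shown here, the comparison with the dimethyl triazole gives much the same picture, with a 1.9-fold lower number from compound 1 to compound 4 (0.27 log units; within the scatter), whereas a 3.7-fold lower number from compound 2 to compound 4 (0.57 log units; beyond the scatter) is the one new step that goes beyond the scatter, and it is modest, so compound 2 stays apart from both tetrazole compounds. Nothing measured here explains why the larger group leaves the number in the same range.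

Compound 4 differs from compound 3 both in the added phenyl and in how the tetrazole is attached, 5-phenyl-1H-tetrazol-1-yl against 2H-tetrazol-2-yl, and the compounds shown do not separate these two changes. Also open, on these data alone, is what happens with an amine or a carboxylic acid on the added phenyl ring, or with a benzyl group in place of that phenyl.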